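The source may report more compounds than this note shows. Statements on the series, on what has been measured and on what is new or still open speak of the compounds shown alone.

Measured compounds: compound 1 `CN1CCCN(CCn2ccc3ccc(Cl)cc32)CC1` gives 34 nM in an assay on HEK293 cells for binding affinity to 5-hydroxytryptamine receptor 7 (Homo sapiens), read by radioligand binding; a higher number here means a weaker inhibitor, a lower number a stronger inhibitor; compound 2 `CN1CCCN(CCn2ccc3ccc(OCc4ccccc4)cc32)CC1` gives 182 nM; compound 3 `C=Cc1ccc2ccn(CCN3CCCN(C)CC3)c2c1` gives 109 nM.

Compound 3 holds the second-highest number of the three: the nearest step is a 1.7-fold lower number from compound 2 to compound 3 (0.22 log units; within the scatter), while compound 1 lies further off, a 3.2-fold higher number from compound 1 to compound 3 (0.51 log units; beyond the scatter). Compound 4 `C=C(C)c1ccc2ccn(CCN3CCCN(C)CC3)c2c1` differs from compound 3 by methyl in place of hydrogen on a double-bonded chain carbon bound to an aromatic carbon. Going by the values given here, no measured step adds a methyl anywhere; the only steps at this aromatic carbon, a 5.4-fold higher number from compound 1 to compound 2 (0.73 log units; beyond the scatter) and a 3.2-fold higher number from compound 1 to compound 3 (0.51 log units; beyond the scatter), swap whole groups and so bear only loosely on a single added methyl. A step no larger than the scatter is therefore expected in this assay, a 1.1-fold higher number from compound 3 to compound 4 (0.04 log units; within the scatter). Compound 4 is estimated at 120 nM, within 50 nM to 300 nM.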

Compound 4, inhibition constant: 70 nM
Compound 4: middle estimate off by 1.7-fold (0.23 log units), on the high side; measured number inside the range.
By their numbers in this assay, from the lowest: compound 1; then compounds 4, 3 and 2 (each within the scatter of the next, the first and the last beyond it).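

In this assay the added methyl gives a 1.6-fold lower number from compound 3 to compound 4 (0.19 log units; within the scatter) and so leaves the number at this aromatic carbon within the scatter. The 1-methylethenyl group does stand clear of benzyloxy with a 2.6-fold lower number from compound 2 to compound 4 (0.41 log units; beyond the scatter) where vinyl did not, yet it remains apart from chloro with a 2.1-fold higher number from compound 1 to compound 4 (0.31 log units; beyond the scatter) and chloro keeps the lowest number of the four. Nothing available explains these steps. As far as these compounds go, whether a nitrile, an amine or a bromo group at this carbon would match or pass chloro stays open.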